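The source may report more compounds than this note shows. Statements on the series, on what has been measured and on what is new or still open speak of the compounds shown alone.

Of the compounds shown here, three have been measured in a physicochemical assay for lipophilicity, measured as octanol-water partition; on this read-out higher numbers stand for higher lipophilicity and lower numbers for lower lipophilicity. Compound 1, `O=C(COc1cccc2ccccc12)N/N=C/c1ccc(Br)cc1`, gives in this assay 4.81. Compound 2, `O=C(COc1cccc2ccccc12)N/N=C/c1ccccc1O`, gives in this assay 3.73. Compound 3, `C/C(=N\NC(=O)COc1cccc2ccccc12)c1ccccc1O`, gives in this assay 3.08, the lowest of the three numbers and beyond the scatter from both others.

Compounds 2 and 1 differ in one place, (4-bromophenyl in place of 2-hydroxyphenyl on a carbon with a double bond to nitrogen), and this change made a step of a number 1.08 log units higher from compound 2 to compound 1 (beyond the scatter). Compound 4, `C/C(=N\NC(=O)COc1cccc2ccccc12)c1ccc(Br)cc1`, is not yet measured; it stands to compound 3 as compound 1 stands to compound 2, (4-bromophenyl in place of 2-hydroxyphenyl on a carbon with a double bond to nitrogen). The two changes are the same kind of change rather than the same: in compound 2 the carbon that carries the group has as its other neighbour only the double-bonded nitrogen, whereas in compound 3 that carbon also carries a saturated chain carbon. How the core of compound 3 differs from the core of compound 2 is not broken down here.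

Resting on the step from compound 2 to compound 1, compound 3 to compound 4 is expected to rise by about a number 1.08 log units higher from compound 3 to compound 4 (beyond the scatter). Compound 4 is therefore estimated to give in this assay 4.16. The expected range for compound 4 runs from 3.8 to 4.5, because the step of a number 1.08 log units higher from compound 2 to compound 1 (beyond the scatter) was made around a place that is only partly the same.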

Compound 4, partition coefficient: 3.61
Estimate against measurement, compound 4: 0.55 log units above; the whole stated range lies above it.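

In this assay the change to 4-bromophenyl in place of 2-hydroxyphenyl again raises the number, with a number 0.53 log units higher from compound 3 to compound 4 (beyond the scatter), against a number 1.08 log units higher from compound 2 to compound 1 (beyond the scatter) on the other core, so in these two pairs the direction of the step carries over from one core to the other while its size does not. For the compounds shown here, with only two pairs, this shows that the step measured on one core cannot be carried at full size to the other core, but it gives no rule for how much of a step survives such a move, and it says nothing about any other change of group. Nothing measured here bears on why the step is smaller where the carbon with a double bond to nitrogen also carries a saturated chain carbon.

The compounds shown leave open whether the same shrinking of the step would appear with other groups at this place, such as a phenyl ring carrying an amine or a carboxylic acid. They also leave open how the step would run on a core with a longer chain on that carbon in place of the saturated chain carbon of compound 3 and compound 4.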